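The compounds below may be only part of what the source reports. "The series", "measured", "known", "first", "only" and "open" are said of these compounds alone.

Measured compounds in a functional assay on MRC5 cells (Homo sapiens); on this read-out lower numbers stand for higher toxicity in this test and higher numbers for lower toxicity in this test:
Compound 1 `COc1ccc(CN2c3ccccc3C(=O)N(Cc3ccccc3)S2(=O)=O)cc1` gives 61000 nM.
Compound 2 `O=C1c2ccccc2N(Cc2ccc([N+](=O)[O-])cc2)S(=O)(=O)N1Cc1ccccc1` gives only a limit of the assay, > 59000 nM.
Compound 3 `O=C1c2ccccc2N(Cc2ccccc2)S(=O)(=O)N1Cc1ccccc1` gives 66000 nM.

Compound 3 carries the highest of the two numbers actually read in this assay, but its nearest neighbour, compound 1, sits at a distance of a 1.1-fold higher number from compound 1 to compound 3 (0.03 log units; within the scatter), so the two compounds cannot be told apart. Compound 2 stands at the limit (the limit of > 59000 nM in this assay, at which 1 of the 3 values shown sits), which leaves both a step that the limit leaves unreadable from compound 1 to compound 2 and a step that the limit leaves unreadable from compound 2 to compound 3 unreadable in size.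

Compound 4 `O=C1c2ccccc2N(Cc2cccc(Cl)c2)S(=O)(=O)N1Cc1ccccc1` differs from compound 3 by chloro in place of hydrogen on an aromatic carbon.

Going by the values given here, only one measured step bears on this change: the exchange of a methoxy substituent for hydrogen on the same benzyl ring, a 1.1-fold higher number from compound 1 to compound 3 (0.03 log units; within the scatter), which stayed within the scatter. The two steps involving the nitro compound cannot be sized because of the limit (the limit of > 59000 nM in this assay, at which 1 of the 3 values shown sits). The small body of evidence therefore gives no reason to expect a step in this assay beyond the scatter in either direction for a chloro substituent on this ring.

Compound 4 is thus expected to give about 60000 nM in this assay, within a range of 30000 nM to 120000 nM, which means an estimated step of a 1.1-fold lower number from compound 3 to compound 4 (0.04 log units; within the scatter).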

Compound 4, half-maximal cytotoxic concentration: 60000 nM
Estimate against measurement, compound 4: no gap at the digits printed, and the stated range covers the measured number.
By their numbers in this assay, from the lowest: compounds 4, 1 and 3 (each within the scatter of the next).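

In this assay, going by these compounds alone, a substituent on an aromatic carbon meta to a large group can now be read for the first time: the 3-chlorobenzyl group of compound 4, set against the plain benzyl group, gives a 1.1-fold lower number from compound 3 to compound 4 (0.04 log units; within the scatter). The comparison with the 4-methoxyphenyl compound gives a 1.0-fold lower number from compound 1 to compound 4 (0.01 log units; within the scatter), so 3-chlorophenyl and 4-methoxyphenyl cannot be told apart in this test, and compounds 1, 3 and 4 all lie within the scatter of one another. Compound 2 remains a limit and not a number, so the steps that involve it, including the new one, cannot be read: the limit of > 59000 nM in this assay, at which 1 of the 4 values shown sits.

Whether any group on this benzyl ring can move the number beyond the scatter stays open, since a chloro and a methoxy substituent have not done so and an amine or a carboxylic acid at this place is not among the compounds shown. On these data alone, the second benzyl group is the same in all four compounds, so what a longer chain or another group in its place would do in this assay also remains open.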